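Swapping the Aryl Group on a Triazole-Linked Terpenoid Ester

The source may report more compounds than this note shows. Statements on the series, on what has been measured and on what is new or still open speak of the compounds shown alone.

Compound 1 `C/C(=C\CC/C(C)=C/CC[C@@H]1[C@@]2(C)CCC(=O)C(C)(C)[C@H]2CC[C@@]1(C)O)CC/C=C(\C)C(=O)OCc1cn(-c2ccc(F)c(Cl)c2)nn1`: > 150000 nM.
Compound 2 `C/C(=C\CC/C(C)=C/CC[C@@H]1[C@@]2(C)CCC(=O)C(C)(C)[C@H]2CC[C@@]1(C)O)CC/C=C(\C)C(=O)OCc1cn(C[C@@H]2O[C@H](n3ccc(=O)[nH]c3=O)C[C@H]2O)nn1`: 148000 nM.

In an ADME assay on L132 cells (Homo sapiens) for cytotoxicity, read by MTT assay, with a stated time of 48 h (on this read-out lower numbers stand for stronger inhibition and higher numbers for weaker inhibition), compound 1 gives only > 150000 nM, which is a limit of the assay rather than a measured number. Compound 2 gives 148000 nM in this assay. Compound 1 therefore stands at the edge of what this assay reports: the limit of > 150000 nM in this assay, at which 1 of the 2 values shown sits. Among the compounds with values here, no pair of measured compounds differs in just one place, so there is no measured step to lean on when moving to a new compound.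

Compound 3 `C/C(=C\CC/C(C)=C/CC[C@@H]1[C@@]2(C)CCC(=O)C(C)(C)[C@H]2CC[C@@]1(C)O)CC/C=C(\C)C(=O)OCc1cn(-c2ccc(C)cc2)nn1` is built from compound 1 by a single change on the triazole: 4-methylphenyl in place of 3-chloro-4-fluorophenyl on an aromatic nitrogen. Both the group that leaves and the group that enters are small, uncharged aromatic rings with no hydrogen-bond donors or acceptors.

Within the data shown here, with the only close neighbour sitting at a limit, the expected step of a number no higher from compound 1 to compound 3 (the limit leaves the size open) is none beyond the usual scatter of this assay. Compound 3 is therefore expected to come out near 150000 nM in this assay. The estimate for compound 3 spans 60000 nM to 350000 nM, and a result reported only as a limit is quite possible.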

Compound 3, half-maximal inhibitory concentration: > 150000 nM
Compound 3 was reported as a limit; the forecaster's own chance of this, stated with the estimate: 55%; the middle value sits exactly at the limit.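

In this assay compound 3 gives > 150000 nM, which is a limit and not a number. Within the data shown here, compound 1 gives > 150000 nM, also a limit, so no step between compound 1 and compound 3 can be read. As far as these compounds go, whether 4-methylphenyl in place of 3-chloro-4-fluorophenyl changes the result in this assay at all stays open.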